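This account rests on a few compounds, and the source may have more. Where it says the series, first, only, none or still open, it means among the compounds named here.

Compound 1, with the structure `O=c1cc(Cn2ccnc2)c2ccc(OCc3cccc(C(F)(F)F)c3)cc2o1`, was tested in an assay for inhibition of steroid 17-alpha-hydroxylase/17,20 lyase (Homo sapiens), read by HPLC, with a stated time of 5 min, tested at 2.5 uM, in the presence of a further agent that is not named here (on this read-out higher numbers stand for more inhibition at the one concentration tested (going by the name of the read-out) and lower numbers for less inhibition), and gave 0%. Compound 2, with the structure `O=c1cc(Cn2ccnc2)c2ccc(OCc3cccc(F)c3)cc2o1`, differs from compound 1 in one place: a fluoro group takes the position of a trifluoromethyl group on an aromatic carbon. In this assay compound 2 gives 0%, so compound 2 stands level with compound 1, the step of no change at the digits printed from compound 1 to compound 2 (within the scatter) lying within the scatter.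

Compound 3, with the structure `Cc1cccc(COc2ccc3c(Cn4ccnc4)cc(=O)oc3c2)c1`, is not yet measured. It differs from compound 2 by methyl in place of fluoro on an aromatic carbon. Among the compounds with values here, the one step available, from compound 1 to compound 2, also exchanged a group on that same aromatic carbon and brought no change at the digits printed from compound 1 to compound 2 (within the scatter). On that basis the change in compound 3 is expected to bring no change at the digits printed from compound 2 to compound 3 (within the scatter), nothing beyond the scatter. Compound 3 is therefore estimated at 0%, expected to fall between 0% and 12%.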

Compound 3, a percentage reported as inhibition, at one concentration (the size of the read-out at that concentration, not a potency): 0%
Compound 3: the middle estimate sits on the measured number at the digits printed; the measured number falls inside the stated range.
By their numbers in this assay, from the lowest: compounds 1, 2 and 3 (each within the scatter of the next).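

In this assay, methyl in place of fluoro on this aromatic carbon brings no change at the digits printed from compound 2 to compound 3 (within the scatter), and methyl in place of trifluoromethyl brings no change at the digits printed from compound 1 to compound 3 (within the scatter). Compound 3 carries the first group at this place with no fluorine in it, so among these three compounds the read-out stays the same whether or not the group holds fluorine. Nothing measured here explains why the three compounds read alike.

As far as these compounds go, all three sit at the same value, so they give no ranking of these groups, and it remains open whether any group at this place can raise the reading at all, such as an amine, a carboxylic acid or a longer chain. From the compounds shown here alone, it is also open whether compounds 1, 2 and 3 would separate at a concentration other than the single one used.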